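The source may hold more compounds than are shown below. What is called first, only, known or untested is meant among the compounds shown, and "the series" means these compounds.

Measured so far in a functional assay on NIH3T3 cells for agonist activity at Urotensin-2 receptor (Homo sapiens), with a stated time of 5 days; on this read-out lower numbers stand for smaller maximal responses and higher numbers for larger maximal responses:

compound 1, `CN(C)CCC(NC(=O)/C=C/c1ccccc1)c1ccc2ccccc2c1`, gives 116%
compound 2, `CN(C)CCC(NC(=O)CCc1ccccc1)c1ccc(Cl)cc1`, gives 139%
compound 3, `COc1ccc(CCC(=O)NC(CCN(C)C)c2ccc(Cl)cc2)cc1`, gives 101%

Compound 2 and compound 3 differ in one place only: methoxy in place of hydrogen on an aromatic carbon. On this read-out that single change gave a number 38 percentage points lower from compound 2 to compound 3 (beyond the scatter). Compound 1 carries a different core from compound 2; the difference between the two cores is not broken down here. Within the measured set compound 1 sits between the other two, with compound 2 higher and compound 3 lower, both gaps beyond the scatter.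

Compound 4, `COc1ccc(/C=C/C(=O)NC(CCN(C)C)c2ccc3ccccc3c2)cc1`, has not yet been measured in this assay. It differs from compound 1 by methoxy in place of hydrogen on an aromatic carbon. This is the same change that turns compound 2 into compound 3, and the place is described in the same words in both cases; among the compounds shown it occurs two times in all.

For the measured compounds named here, only one measured example of this change exists, so the expectation rests on it alone. Going by the values given here, because the single measured step was a number 38 percentage points lower from compound 2 to compound 3 (beyond the scatter), a drop of similar direction is expected, though on a different core, so the size is uncertain. The expected step from compound 1 to compound 4 in this assay is a number 31 percentage points lower from compound 1 to compound 4 (beyond the scatter). For compound 4 the estimate in this assay is 85%, with a likely range from 60% to 110%.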

Compound 4, largest response reached (reported as efficacy), in percent of the reference or control that the assay uses: 106%
For compound 4 the middle estimate is 21 percentage points below the measured one; the range from low to high includes it.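

In this assay, the change from phenyl to 4-methoxyphenyl on the core of compound 1 gave a number 10 percentage points lower from compound 1 to compound 4 (within the scatter), so on this core the step cannot be told apart from the usual scatter of repeated measurements. For the compounds shown here, the size of the step therefore does not carry over unchanged from one core to the other: the same change on two cores in this assay, a number 38 percentage points lower (beyond the scatter) from compound 2 to compound 3 and a number 10 percentage points lower (within the scatter) from compound 1 to compound 4, 28 percentage points apart, beyond the scatter of two such steps This shows only that the core can matter to the size of the step: with two pairs and with the difference between the cores not broken down, it does not show which part of the core goes with the gap, nor what the step would be on any further core.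

The compounds shown leave open whether the result is particular to methoxy, since no smaller or larger group, such as hydroxy or ethoxy, stands in the same place on either core. They also leave open how the maximal response follows the side chain, since every compound shown carries the same dimethylamino end and none a primary amine or a longer chain.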